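Phenyl added to the acyl chain of compound 2

A few compounds are considered here, and "the series" means these few. Any claim that something is new, unique, unknown or untested is made for them only; others in the source may bear on it.

The shared core carries a bromophenol substituent and an acyl group on ring nitrogen. Compound 1 `CC1=NN(C(=O)CCl)C(c2cc(Br)ccc2O)C1` bears a chloroacetyl group; in a functional assay on PC-3 cells (Homo sapiens) for cytotoxicity, read by MTT assay, with a stated time of 48 h (a lower number here means a stronger inhibitor, a higher number a weaker inhibitor), compound 1 gives 8890 nM. Compound 2 `CCC(=O)N1N=C(C)CC1c1cc(Br)ccc1O` bears a propanoyl group, and in this assay compound 2 gives 37800 nM. Among the measured compounds shown here, the step of a 4.3-fold higher number from compound 1 to compound 2 (0.63 log units; beyond the scatter) is the only measured comparison in the set. Compound 2 thus stands at the higher of the two numbers, the weaker of the pair.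

Compound 3 `CC1=NN(C(=O)CCc2ccccc2)C(c2cc(Br)ccc2O)C1` differs from compound 2 by phenyl in place of hydrogen on a saturated chain carbon, two bonds along the chain from a carbonyl carbon: the propanoyl chain becomes a phenethyl-carbonyl chain. For the measured compounds named here, no measured step touches this position; the one known step concerns the carbon bound to the carbonyl and swapped chloro for methyl, so it bears only indirectly on a phenyl added two bonds further out. Going by the values given here, with no direct precedent, the expected step of a 1.7-fold lower number from compound 2 to compound 3 (0.24 log units; within the scatter) is small and uncertain, leaning towards a lower number because compound 1, with the larger chloro substituent on the chain, sits at 8890 nM. For compound 3 the estimate in this assay is 22000 nM, with a range from 6000 nM to 80000 nM.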

Compound 3, half-maximal inhibitory concentration: 16300 nM
Estimate against measurement, compound 3: 1.3-fold (0.13 log units) above; the measured number falls inside the stated range.
By their numbers in this assay, from the lowest: compounds 1 and 3 (each within the scatter of the next); then compound 2.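

In this assay, among the compounds shown here, the saturated chain carbon two bonds along the chain from a carbonyl carbon takes phenyl in place of hydrogen with a modest drop in the number (a 2.3-fold lower number from compound 2 to compound 3 (0.37 log units; beyond the scatter)), the first reading at this position. Set against compound 1, compound 3 cannot be told apart (a 1.8-fold higher number from compound 1 to compound 3 (0.26 log units; within the scatter)), so on the saturated chain carbon bound to a carbonyl carbon, chloro and benzyl both give numbers beyond the scatter from methyl in compound 2 and within the scatter of each other. No measured information on these compounds accounts for the shift seen with phenyl.

The compounds shown leave open whether the step belongs to the aromatic ring itself or simply to the added carbons, a question that a butyl or hexyl chain on the carbonyl would address directly. They also leave open how far this chain position tolerates other groups, such as a terminal amine, a carboxylic acid, or a phenyl ring carrying methoxy or fluoro.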